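Moving the Methyl Around the Imidazole Substituent

The source may report more compounds than this note shows. Statements on the series, on what has been measured and on what is new or still open speak of the compounds shown alone.

Compound 1 `CCc1nc(C)c(CN2CCN(c3cccc4[nH]c(-c5ccc(C(C)(C)C)cc5)nc34)CC2)o1` — 320 nM
Compound 2 `CCCn1cnc(CN2CCN(c3cccc4[nH]c(-c5ccc(C(C)(C)C)cc5)nc34)CC2)c1C` — 47 nM
Compound 3 `CCCCn1cnc(CN2CCN(c3cccc4[nH]c(-c5ccc(C(C)(C)C)cc5)nc34)CC2)c1C` — 49 nM

In an assay on isolated protein for displacement of a labelled ligand from Gonadotropin-releasing hormone receptor (Rattus norvegicus) (on this read-out lower numbers stand for stronger inhibition and higher numbers for weaker inhibition), compound 3 stands second highest of the three numbers, with compound 2 within the scatter and compound 1 clearly higher. Compound 4 `CCCn1cc(CN2CCN(c3cccc4[nH]c(-c5ccc(C(C)(C)C)cc5)nc34)CC2)nc1C` differs from compound 3 by 2-methyl-1-propyl-1H-imidazol-4-yl in place of 1-butyl-5-methyl-1H-imidazol-4-yl on a saturated chain carbon bound to an amine nitrogen in a ring. The step of a 1.0-fold higher number from compound 2 to compound 3 (0.02 log units; within the scatter) shows that butyl against propyl on the imidazole makes no difference beyond the scatter, while a 6.8-fold lower number from compound 1 to compound 2 (0.83 log units; beyond the scatter) and a 6.5-fold lower number from compound 1 to compound 3 (0.81 log units; beyond the scatter) show both imidazoles well ahead of the oxazole. Within the data shown here, no measured pair tests the rearrangement within the imidazole ring itself, so the expectation rests on the two imidazoles behaving alike, with wider uncertainty. Compound 4 is therefore expected at 70 nM, between 25 nM and 250 nM, which is an expected 1.4-fold higher number from compound 3 to compound 4 (0.15 log units; within the scatter), no change beyond the scatter.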

Compound 4, half-maximal inhibitory concentration in the Gonadotropin-releasing hormone receptor assay: 41 nM
For compound 4 the middle estimate is 1.7-fold (0.23 log units) above the measured one; the measured number falls inside the stated range.
By their numbers in the Gonadotropin-releasing hormone receptor assay, from the lowest: compounds 4, 2 and 3 (each within the scatter of the next); then compound 1.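

In the Gonadotropin-releasing hormone receptor assay, 2-methyl-1-propyl-1H-imidazol-4-yl matches the other imidazoles, with a 1.2-fold lower number from compound 3 to compound 4 (0.08 log units; within the scatter) and a 1.1-fold lower number from compound 2 to compound 4 (0.06 log units; within the scatter), and it keeps the lead over the oxazole, with a 7.8-fold lower number from compound 1 to compound 4 (0.89 log units; beyond the scatter). This position therefore accepts a further arrangement of the imidazole without a change beyond the scatter. In a physicochemical assay for solubility, at pH 7.4 (on this read-out lower numbers stand for lower solubility and higher numbers for higher solubility), compound 3 gives 3 ug/mL and compound 4 gives 55 ug/mL. In the physicochemical assay the same change does separate the compounds: the measured solubility of compound 3, 3 ug/mL, and of compound 4, 55 ug/mL, an 18-fold higher number (1.26 log units; beyond the scatter)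

The compounds shown do not tell whether that gap follows the propyl chain in place of butyl or the new place of the methyl on the imidazole. From the compounds shown here alone, how a hydroxyl or an amine on that chain would fare in either read-out also stays open.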